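Furan-2-yl for Phenyl on the Amide of Compound 1

The compounds below may be only part of what the source reports. "The series", "measured", "known", "first", "only" and "open" are said of these compounds alone.

Of the compounds shown here, three of a shared core have been tested in an assay on CHO cells for displacement of a labelled ligand from adenosine receptor A1 (Homo sapiens), read by scintillation counting, with a stated time of 120 min, tested at 1 uM; on this read-out lower numbers stand for less inhibition and higher numbers for more inhibition at the one concentration tested (going by the name of the read-out). Compound 1 `Cc1nc(NC(=O)c2ccccc2)c2nn(-c3ccccc3)cc2n1` gives 30% in this assay. Compound 2 `COc1ccc(-n2cc3nc(Cc4ccccc4)nc(N)c3n2)cc1` gives 40%, a number that lies within the usual scatter of the number for compound 1, so the two cannot be told apart. Compound 3 `O=C(Nc1nc(-c2ccccc2)nc2cn(-c3ccccc3)nc12)c1ccncc1` gives 1%, a number beyond the scatter below that of compound 1. On the three numbers, compound 1 stands second highest, with compound 2 nearest and compound 3 furthest.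

Compound 4 `Cc1nc(NC(=O)c2ccco2)c2nn(-c3ccccc3)cc2n1` has not yet been measured in this assay. Relative to compound 1 the counted difference is furan-2-yl in place of phenyl on a carbonyl carbon. Within the data shown here, no pair of measured compounds differs by just this change, so the size of its step is not known from the data. Since a carbonyl-linked aromatic ring is swapped for another aromatic ring on the same carbonyl carbon, the step is expected to be small and not clearly beyond the scatter, perhaps slightly downward. For compound 4 the number expected in this assay is 25%, within a range from 5% to 50%, meaning an expected step of a number 5 percentage points lower from compound 1 to compound 4 (within the scatter).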

Compound 4, a percentage reported as inhibition, at one concentration (the size of the read-out at that concentration, not a potency): 20%
Estimate against measurement, compound 4: 5 percentage points above; measured number inside the range.
By their numbers in this assay, from the lowest: compound 3; then compounds 4, 1 and 2 (each within the scatter of the next, the first and the last beyond it).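

In this assay, among these compounds, furan-2-yl in place of phenyl on a carbonyl carbon gives a number 10 percentage points lower from compound 1 to compound 4 (within the scatter), the first step that can be read directly, as the earlier compounds differed from one another in more than one place. It shows that, at this position, a six-membered aromatic ring of carbon only can give way to a five-membered aromatic ring with one hetero atom, bringing one hydrogen-bond acceptor and one heavy atom fewer, with no change that can be told from the usual scatter. Nothing available explains why the exchange leaves the read-out within that scatter.

The compounds shown leave open whether this position would accept something other than an aromatic ring on the carbonyl carbon, such as cyclohexyl, a longer alkyl chain, a primary amine or a carboxylic acid. They also leave open how compound 1 and compound 4 would compare as potencies, as the read-out reports inhibition at one concentration only.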